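Working notes: compound 3 to compound 4

The source may report more compounds than this note shows. Statements on the series, on what has been measured and on what is new or still open speak of the compounds shown alone.

Among the compounds with values here, in a functional assay on KYSE-410 cells (Homo sapiens) for antiproliferative activity, read by MTT assay, with a stated time of 72 h (on this read-out lower numbers stand for stronger inhibition and higher numbers for weaker inhibition), compound 1 (`COc1ccc(-c2ccc3c(C(=O)Nc4cccc(F)c4)cc(=O)[nH]c3c2)cc1`) gives 18000 nM, the only true number so far. Compound 2 (`Cc1ccc(-c2ccc3c(C(=O)Nc4cccc(F)c4)cc(=O)[nH]c3c2)cc1`) reads > 20000 nM, which is a limit of the assay. Compound 3 (`O=C(Nc1cccc(F)c1)c1cc(=O)[nH]c2cc(-c3ccncc3)ccc12`) reads > 20000 nM, which is also a limit and not a number. Compound 3 therefore stands at the limit of > 20000 nM in this assay, at which 2 of the 3 values shown sit.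

Compound 4 (`O=C(Nc1cccc(F)c1)c1cc(=O)[nH]c2cc(-c3cccnc3F)ccc12`) carries 2-fluoropyridin-3-yl in place of pyridin-4-yl on an aromatic carbon.

Within the data shown here, no measured step covers this exchange directly. The nearest evidence comes from the other changes of group at the same place. These are an at least 1.1-fold higher number from compound 1 to compound 2 (0.04 log units; that floor lies within the scatter) and an at least 1.1-fold higher number from compound 1 to compound 3 (0.04 log units; that floor lies within the scatter). The third comparison gives a step that the two limits leave unreadable from compound 2 to compound 3. None of these shows a change beyond the scatter, and compound 1 at 18000 nM gives the only numerical anchor.

No step beyond the scatter is therefore expected in this assay, and no direction is favoured. The expected step is a number no higher from compound 3 to compound 4 (the limit leaves the size open). A further reading at the limit is the most likely outcome. The estimated value for compound 4 is 20000 nM, with an expected range from 9000 nM to 40000 nM.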

Compound 4, half-maximal inhibitory concentration: 11600 nM
Estimate against measurement, compound 4: 1.7-fold (0.24 log units) above; the measured number falls inside the stated range.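

In this assay compound 4 gives 11600 nM, so this aromatic carbon of the shared core now carries a second true number, and a group with a six-membered aromatic ring holding a hetero atom reads inside the range of the assay. The exchange of pyridin-4-yl for 2-fluoropyridin-3-yl gives an at least 1.7-fold lower number from compound 3 to compound 4 (0.23 log units; that floor lies within the scatter), and the exchange of 4-methylphenyl for the same group gives an at least 1.7-fold lower number from compound 2 to compound 4 (0.23 log units; that floor lies within the scatter), so the reading leaves the limit but neither floor goes beyond the scatter. Set against the 4-methoxyphenyl group, the result is a 1.6-fold lower number from compound 1 to compound 4 (0.19 log units; within the scatter), so the two true numbers at this position do not separate.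

The step between the two compounds that stand at a limit cannot be read, and no group shown yet separates beyond the scatter from the others: the limit of > 20000 nM in this assay, at which 2 of the 4 values shown sit.

Open still is whether the fluorine or the place of the ring nitrogen carries the change, for which plain pyridin-3-yl would be the comparison in one place, and how an amine such as piperidin-4-yl, a carboxylic acid or a longer chain would read on this carbon.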